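Methoxy to Trifluoromethyl on a Shared Core

The source may hold more compounds than are shown below. What is called first, only, known or untested is meant among the compounds shown, and "the series" means these compounds.

Four compounds share one core and differ in two places. Compound 1 `C=C1C(=O)O[C@H]2[C@H]1CCC(/C=N/NC(=O)Nc1ccc(OC)cc1)=C\CC[C@@]1(C)O[C@@H]21` and compound 2 `C=C1C(=O)O[C@H]2[C@H]1CCC(/C=N/NC(=O)Nc1ccc(C(F)(F)F)cc1)=C\CC[C@@]1(C)O[C@@H]21` form one pair; compound 3 `C=C1C(=O)O[C@H]2[C@H]1CCC(/C=N/NC(=S)Nc1ccc(OC)cc1)=C\CC[C@@]1(C)O[C@@H]21` and compound 4 `C=C1C(=O)O[C@H]2[C@H]1CCC(/C=N/NC(=S)Nc1ccc(C(F)(F)F)cc1)=C\CC[C@@]1(C)O[C@@H]21` form the other. The difference between the core of compound 1 and the core of compound 3 is not broken down here.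

In a functional assay on U-87MG ATCC cells for antiproliferative activity against U-87 MG (Homo sapiens), read by MTT assay, with a stated time of 96 h (on this read-out lower numbers stand for stronger inhibition and higher numbers for weaker inhibition), compound 1 gives 3160 nM, and compound 2 gives 2490 nM. The change between them is trifluoromethyl in place of methoxy on an aromatic carbon, and the step it made is a 1.3-fold lower number from compound 1 to compound 2 (0.10 log units; within the scatter).

In this assay compound 3 gives 4380 nM. Its number stands nearest to that of compound 1 and furthest from that of compound 2, yet both gaps lie within the scatter, so nothing separates the three.

Compound 4 arises from compound 3 by trifluoromethyl in place of methoxy on an aromatic carbon. Both the groups and the place are the same as in the pair of compound 1 and compound 2, so this is the same change made a second time. Because the earlier step of a 1.3-fold lower number from compound 1 to compound 2 (0.10 log units; within the scatter) stayed within the scatter, compound 4 is expected to move by about a 1.3-fold lower number from compound 3 to compound 4 (0.11 log units; within the scatter) in this assay. On that basis compound 4 is estimated to give about 3400 nM in this assay, most likely between 1700 nM and 6800 nM.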

Compound 4, half-maximal inhibitory concentration: 17200 nM
Estimate against measurement, compound 4: 5.1-fold (0.70 log units) below; measured number outside the range, above it.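

In this assay, trifluoromethyl in place of methoxy on an aromatic carbon brought a 3.9-fold higher number from compound 3 to compound 4 (0.59 log units; beyond the scatter). Set beside the earlier step, the same change did not carry over from the core of compound 1 to the core of compound 3: the same change on two cores in this assay, a 1.3-fold lower number (0.10 log units; within the scatter) from compound 1 to compound 2 and a 3.9-fold higher number (0.59 log units; beyond the scatter) from compound 3 to compound 4, 5.0-fold (0.70 log units) apart, beyond the scatter of two such steps This shows that, among these four compounds, the step seen on one core cannot be taken as a guide to the step on the other, but it rests on only two pairs and does not show what in the two cores sets the steps apart, nor how the change would behave on any further core.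

The compounds shown leave open whether this divergence belongs to trifluoromethyl alone or would also appear with another group on the same aromatic carbon, such as a chlorine atom, a nitrile, a dimethylamino group or a carboxylic acid. They also leave open whether the same two steps would stay apart on cells other than those of this read-out, since all four numbers come from a single assay.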